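This account rests on a few compounds, and the source may have more. Where it says the series, first, only, none or still open, it means among the compounds named here.

Series notes. Compound 1 `Cc1cc(C)nc(Oc2ccc(NC(=O)Nc3ccc(F)cc3)cc2)n1` and compound 2 `Cc1cc(C)nc(Oc2ccc(NC(=O)Nc3ccc(Cl)cc3)cc2)n1` share one core, while compound 3 `Cc1cc(C)nc(Sc2ccc(NC(=O)Nc3ccc(F)cc3)cc2)n1` and compound 4 `Cc1cc(C)nc(Sc2ccc(NC(=O)Nc3ccc(Cl)cc3)cc2)n1` share another; the difference between the two cores is not broken down here. In a functional assay on KB cells (Homo sapiens) for cytotoxicity, read by MTT assay, with a stated time of 3 days (a higher number here means a weaker inhibitor, a lower number a stronger inhibitor), compound 1 gives 48400 nM, and compound 2 gives 25400 nM. The change from compound 1 to compound 2 is chloro in place of fluoro on an aromatic carbon and the step it made was a 1.9-fold lower number from compound 1 to compound 2 (0.28 log units; within the scatter). In this assay compound 3 gives 32100 nM, which lies within the scatter of both compound 2 and compound 1, so no order among the three measured compounds can be stated.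

Compound 4 has not yet been measured. For the measured compounds named here, it differs from compound 3 by chloro in place of fluoro on an aromatic carbon, the same change as the one from compound 1 to compound 2, at the same place, and this change occurs twice among the four compounds. For compound 4 in this assay the expected step is a 1.8-fold lower number from compound 3 to compound 4 (0.25 log units; within the scatter), set beside the earlier step of a 1.9-fold lower number from compound 1 to compound 2 (0.28 log units; within the scatter), and this expectation rests on that one pair alone, so the range is kept wide. Compound 4 is accordingly estimated at 18000 nM, between 8000 nM and 40000 nM.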

Compound 4, half-maximal inhibitory concentration: 10200 nM
For compound 4 the middle estimate is 1.8-fold (0.25 log units) above the measured one; low and high end bracket the measured number.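

In this assay, chloro in place of fluoro gives a 3.1-fold lower number from compound 3 to compound 4 (0.50 log units; beyond the scatter), whereas the same change on the core of compound 1 stays within the scatter. Set side by side, the two steps cannot be told apart: the same change on two cores in this assay, a 1.9-fold lower number (0.28 log units; within the scatter) from compound 1 to compound 2 and a 3.1-fold lower number (0.50 log units; beyond the scatter) from compound 3 to compound 4, 1.7-fold (0.22 log units) apart, within the scatter of two such steps. The change therefore carries over between these two cores in direction and, within the scatter, in size, but this rests on two pairs only and does not show that the step is larger on the core of compound 3, nor how it would behave on any further core.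

The compounds shown leave open whether the lower number is particular to chloro or extends to other groups at this place, such as bromo, methyl or trifluoromethyl. Also open, going by these compounds, is what an amine, a carboxylic acid or a longer chain would do there, since only fluoro and chloro appear at this position on the two cores.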